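The source may report more compounds than this note shows. Statements on the series, on what has been measured and on what is new or still open speak of the compounds shown alone.

Measured compounds:
compound 1, `C=CCCCCCCCS(=O)(=O)/C=C/c1ccc(O)c(O)c1`, in a functional assay, read by fluorescence and spectrophotometry, with a stated time of 1 h (on this read-out higher numbers stand for an effect only at larger amounts of compound and lower numbers for an effect already at smaller amounts), compound 1 gives 6900 nM.
compound 2, `O=S(=O)(/C=C/c1ccc(O)c(O)c1)CC1CC1`, in this assay compound 2 gives 10500 nM.

Compound 1 has the lower of the two numbers, yet the gap to compound 2 lies within the scatter, so the two read as alike. Compound 3, `CCCCCCS(=O)(=O)/C=C/c1ccc(O)c(O)c1`, is not yet measured. It differs from compound 1 by hydrogen in place of allyl on a saturated chain carbon, six bonds along the chain from a sulfonyl sulfur. Within the data shown here, no step between measured compounds shows what shortening the chain does, so only a small step is expected, if any beyond the scatter. Compound 3 is estimated at 8500 nM, within 3000 nM to 25000 nM, an expected step of a 1.2-fold higher number from compound 1 to compound 3 (0.09 log units; within the scatter).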

Compound 3, half-maximal effective concentration: 7300 nM
For compound 3 the middle estimate is 1.2-fold (0.07 log units) above the measured one; the range from low to high includes it.
By their numbers in this assay, from the lowest: compounds 1, 3 and 2 (each within the scatter of the next).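

In this assay hydrogen in place of allyl, six bonds along the chain from a sulfonyl sulfur, gives a 1.1-fold higher number from compound 1 to compound 3 (0.02 log units; within the scatter) and so the allyl end, with its double bond, makes no difference beyond the scatter here. Pentyl in place of cyclopropyl on the saturated chain carbon bound to a sulfonyl sulfur gives a 1.4-fold lower number from compound 2 to compound 3 (0.16 log units; within the scatter) and so compound 2, with its ring, and compound 3, with its open chain, read as alike. Nothing measured here offers a reason for this sameness.

Still open, on these data alone, is whether an amine or a carboxylic acid on this chain would move the number beyond the scatter. A much shorter chain, such as methyl on the sulfonyl sulfur, also remains an open question.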